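The source may report more compounds than this note shows. Statements on the series, on what has been measured and on what is new or still open speak of the compounds shown alone.

Working notes on the series.

Two compounds in the series have numbers in a functional assay on PC-3 cells (Homo sapiens) for cytotoxicity, read by sulforhodamine B assay, with a stated time of 48 h, tested at 0.01 uM; a lower number here means a stronger effect, a higher number a weaker effect of the compound at the concentration tested. Compound 1 `COc1cc(-c2cc(/C=C/C(=O)c3ccc(Cl)c(Cl)c3)[nH]n2)cc(OC)c1OC` gives 95%. Compound 2 `COc1ccc(C(=O)/C=C/c2cc(-c3cc(OC)c(OC)c(OC)c3)n[nH]2)cc1` gives 99%. Among the compounds with values here, on these two numbers compound 2 stands highest, with compound 1 nearest; the only measured step, a number 4 percentage points higher from compound 1 to compound 2 (within the scatter), lies within the scatter, so no order between the two can be claimed.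

Compound 3 `COc1cc(-c2cc(/C=C/C(=O)c3ccc(F)c(F)c3)[nH]n2)cc(OC)c1OC` has not been measured. It differs from compound 2 in one place: 3,4-difluorophenyl in place of 4-methoxyphenyl on a carbonyl carbon.

Within the data shown here, the one step that bears on this change is the exchange on the same carbonyl carbon, a number 4 percentage points higher from compound 1 to compound 2 (within the scatter), where a 3,4-dichlorophenyl and a 4-methoxyphenyl gave numbers within the scatter of each other. The new change puts a 3,4-difluorophenyl at that position. Among the measured compounds shown here, with only this comparison available, the expected step of a number 3 percentage points lower from compound 2 to compound 3 (within the scatter) in this assay is none beyond the scatter. Compound 3 is therefore estimated at 96%, with a range from 85% to 105%.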

Compound 3, a percentage reported as activity, at one concentration (the size of the read-out at that concentration, not a potency): 98%
Compound 3: the middle estimate sits 2 percentage points below what was measured; measured number inside the range.
By their numbers in this assay, from the lowest: compounds 1, 3 and 2 (each within the scatter of the next).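

In this assay, a number 1 percentage points lower from compound 2 to compound 3 (within the scatter), and a number 3 percentage points higher from compound 1 to compound 3 (within the scatter), so 3,4-difluorophenyl on a carbonyl carbon cannot be told apart from either 4-methoxyphenyl or 3,4-dichlorophenyl. The position now has three groups compared directly, and the exchange of chlorine for fluorine on the same phenyl pattern, which the earlier pair did not cover, also gives no readable difference at the single concentration tested. No measurement at hand offers an explanation for these numbers.

On these data alone, all three groups on this carbonyl carbon carry one six-membered aromatic ring of carbon only, so it remains open whether a group of another kind, such as an amine like morpholine, a carboxylic acid on the phenyl ring or a longer alkyl chain, would separate from them in this read-out. As far as these compounds go, it also remains open whether these three compounds, indistinguishable at this one concentration, would separate at other concentrations, and a full concentration series would be needed to show whether any of them has a stronger or weaker effect at those concentrations.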